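Three Amide Side-Chains and an Untested Mirror Image

The source may report more compounds than this note shows. Statements on the series, on what has been measured and on what is new or still open speak of the compounds shown alone.

Among the compounds with values here, compound 2 `CCCCCCCCc1ccc(NC(=O)C(N)C(C)(C)O)cc1` gives 2100 nM in an assay on isolated protein for inhibition of sphingosine kinase 1 (Homo sapiens), read by mobility shift assay (a higher number here means a weaker inhibitor, a lower number a stronger inhibitor), the second highest of the three numbers measured so far. Compound 1 `CCCCCCCCc1ccc(NC(=O)[C@H](N)CO)cc1` gives 5000 nM in this assay, and the step of a 2.4-fold lower number from compound 1 to compound 2 (0.38 log units; beyond the scatter) is modest. Compound 3 `CCCCCCCCc1ccc(NC(=O)[C@@H](N)[C@@H](C)O)cc1` gives 650 nM in this assay, with a 7.7-fold lower number from compound 1 to compound 3 (0.89 log units; beyond the scatter) and a 3.2-fold lower number from compound 2 to compound 3 (0.51 log units; beyond the scatter).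

Compound 4 `CCCCCCCCc1ccc(NC(=O)[C@H](N)[C@H](C)O)cc1` differs from compound 2 as follows: 1-amino-2-hydroxypropyl in place of 1-amino-2-hydroxy-2-methylpropyl on a carbonyl carbon. Within the data shown here, compound 4 carries the same atoms as compound 3 but with the opposite arrangement at the two defined stereocentres, and nothing measured so far shows how much that arrangement matters. The closest guide is the step of a 3.2-fold lower number from compound 2 to compound 3 (0.51 log units; beyond the scatter), which suggests the same change in the same direction. The stereocentres differ, so the size is uncertain. Compound 4 is therefore expected to give a somewhat lower number than compound 2, an estimated 1.1-fold lower number from compound 2 to compound 4 (0.02 log units; within the scatter), landing at 2000 nM with a likely range from 500 nM to 8000 nM.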

Compound 4, half-maximal inhibitory concentration: 2100 nM
Beside the measured number, compound 4's estimate is 1.1-fold (0.02 log units) below it; low and high end bracket the measured number.
By their numbers in this assay, from the lowest: compound 3; then compounds 2 and 4 (each within the scatter of the next); then compound 1.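

The side-chain's atoms alone do not set the number in this assay, as the 1-amino-2-hydroxypropyl group gives a 3.2-fold higher number from compound 3 to compound 4 (0.51 log units; beyond the scatter) when its stereocentres are inverted, and the cause of that step can be named: the fact that compounds 3 and 4 differ only in the configuration as drawn. Even in the weaker of these two arrangements, methyl in place of hydrogen on the side-chain of compound 1 gives a 2.4-fold lower number from compound 1 to compound 4 (0.38 log units; beyond the scatter), a smaller step than the one to its mirror-image partner. Compound 4 also shows no change at the digits printed from compound 2 to compound 4 (within the scatter), so in this arrangement, 1-amino-2-hydroxypropyl and 1-amino-2-hydroxy-2-methylpropyl cannot be told apart in this assay.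

The two mixed arrangements of the 1-amino-2-hydroxypropyl group remain open, since only the fully inverted pair is shown here. Also open, going by these compounds, is how a longer chain, such as 1-amino-2-hydroxybutyl, would compare.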